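The source may report more compounds than this note shows. Statements on the series, on what has been measured and on what is new or still open speak of the compounds shown alone.

In a functional assay on SK-MEL-5 cells (Homo sapiens) for cytotoxicity, read by sulforhodamine B assay, with a stated time of 48 h, tested at 0.01 uM (a higher number here means a weaker effect of the compound at the concentration tested, a lower number a stronger effect), compound 1 `COc1cc(-c2cc(/C=C/C(=O)c3ccc(N)cc3)[nH]n2)cc(OC)c1OC` gives 95%, and compound 2 `COc1ccc(C(=O)/C=C/c2cc(-c3cc(OC)c(OC)c(OC)c3)n[nH]2)cc1OC` gives 97%. Going by the values given here, of the two numbers measured so far, compound 2 stands at the top, but the only step, a number 2 percentage points higher from compound 1 to compound 2 (within the scatter), lies within the scatter, so the two readings cannot be told apart. That step exchanged one group on the carbonyl carbon for another, 3,4-dimethoxyphenyl in place of 4-aminophenyl.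

Compound 3 `COc1cc(-c2cc(/C=C/C(=O)c3ccc(F)c(F)c3)[nH]n2)cc(OC)c1OC` has not yet been tested in this assay. It differs from compound 2 at the same spot, namely (3,4-difluorophenyl in place of 3,4-dimethoxyphenyl on a carbonyl carbon). Among the compounds with values here, the one measured step that bears on this change is the earlier swap on the same carbonyl carbon, which moved the reading a number 2 percentage points higher from compound 1 to compound 2 (within the scatter). With a single comparison at this position, and that one inside the scatter, there is no ground to expect a step beyond the scatter in this assay in either direction. Compound 3 is therefore expected to give about 95%, with a range from 82% to 104%. The estimated step, a number 2 percentage points lower from compound 2 to compound 3 (within the scatter), is expected to stay within the scatter.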

Compound 3, a percentage reported as activity, at one concentration (the size of the read-out at that concentration, not a potency): 98%
Compound 3: the middle estimate sits 3 percentage points below what was measured; low and high end bracket the measured number.
By their numbers in this assay, from the lowest: compounds 1, 2 and 3 (each within the scatter of the next).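

In this assay, 3,4-difluorophenyl on the carbonyl carbon gives a number 1 percentage points higher from compound 2 to compound 3 (within the scatter), and in place of 4-aminophenyl it gives a number 3 percentage points higher from compound 1 to compound 3 (within the scatter). A single earlier step could not say much about this position, but three different groups now sit there without any pair of readings being told apart, even though 3,4-dimethoxyphenyl counts 2 hydrogen-bond acceptors and 3,4-difluorophenyl counts 0. At this one test concentration, then, the position has not yet shown a change of group that moves the reading beyond the scatter, and nothing available explains why the three readings stay so close.

Going by these compounds, the three compounds all keep a substituted phenyl ring on the carbonyl carbon, so it remains open whether a different kind of group there, such as a small methyl, a morpholine ring or a phenyl ring carrying a carboxylic acid, would produce a step beyond the scatter. On these data alone, it also remains open whether the three phenyl groups would still give matching readings at a higher test concentration.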